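Cyclohexylcarbamoyl in Place of Diethylamino on Compound 2

The source may hold more compounds than are shown below. What is called first, only, known or untested is meant among the compounds shown, and "the series" means these compounds.

For the measured compounds named here, compound 2 `CCN(CC)C(=O)NCC/C(=C(\c1ccccc1)c1ccc(OC)cc1)c1ccccc1` is the only compound here with a measured number: in a functional assay on MDA-MB-231 cells (Homo sapiens) for cytotoxicity, read by MTT assay, with a stated time of 72 h (on this read-out lower numbers stand for stronger inhibition and higher numbers for weaker inhibition), compound 2 gives 40700 nM. Compound 1 `CCOC(=O)C(=O)NCC/C(=C(\c1ccccc1)c1ccc(OC)cc1)c1ccccc1` sits at the limit of > 50000 nM in this assay, at which 1 of the 2 values shown sits, so in this assay compound 1 gives > 50000 nM, a limit rather than a number. Going by the values given here, the one measured step, an at least 1.2-fold lower number from compound 1 to compound 2 (0.08 log units; that floor lies within the scatter), stays within the scatter. Compound 3 `COc1ccc(/C(=C(/CCNC(=O)C(=O)NC2CCCCC2)c2ccccc2)c2ccccc2)cc1` has not been tested yet; its change from compound 2 is cyclohexylcarbamoyl in place of diethylamino on a carbonyl carbon. Among the compounds with values here, no measured step covers that swap, and the only step seen is small, so the number for compound 3 is expected to shift by about a 1.1-fold higher number from compound 2 to compound 3 (0.04 log units; within the scatter). Compound 3 is therefore estimated at 45000 nM, between 20000 nM and 100000 nM.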

Compound 3, half-maximal inhibitory concentration: 12200 nM
Compound 3: middle estimate off by 3.7-fold (0.57 log units), on the high side, and the stated range ends above it.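

For the compounds shown here, this position responds to change: in this assay, swapping diethylamino for cyclohexylcarbamoyl gives a 3.3-fold lower number from compound 2 to compound 3 (0.52 log units; beyond the scatter), the first step here that clears the scatter. On the same kind of carbonyl carbon, cyclohexylamino in place of ethoxy gives an at least 4.0-fold lower number from compound 1 to compound 3 (0.61 log units; beyond the scatter). This second step starts from a limit rather than a number: the limit of > 50000 nM in this assay, at which 1 of the 3 values shown sits.

Compound 3 brings in the cyclohexyl ring and the extra carbonyl together, so the compounds shown cannot separate their contributions. On these data alone, whether a phenylamino group or an open hexylamino chain in place of cyclohexylamino would keep this gain remains open.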